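The source may hold more compounds than are shown below. What is called first, only, known or untested is meant among the compounds shown, and "the series" means these compounds.

In an ADME assay on THP-1 cells (Homo sapiens) for inhibition, read by MTT assay, with a stated time of 48 h (on this read-out lower numbers stand for stronger inhibition and higher numbers for weaker inhibition), compound 1 `O=C(OC[C@H]1O[C@@H](n2cc(COc3ccc4c(-c5ccccc5)cc(=O)oc4c3)nn2)[C@H](OC(=O)c2ccccc2)[C@@H]1OC(=O)c1ccccc1)c1ccccc1` gives only a limit, > 196000 nM. Compound 2 `Cc1cc(=O)oc2cc(OCc3cn([C@@H]4O[C@H](CO)[C@@H](O)[C@H]4O)nn3)ccc12` also gives only a limit in this assay, > 385000 nM. Both readings therefore sit at the edge of what this assay can report, as the limit of > 196000 nM in this assay, at which 1 of the 2 values shown sits, and the limit of > 385000 nM in this assay, at which 1 of the 2 values shown sits, show. Compound 3 `O=c1cc(-c2ccccc2)c2ccc(OCc3cn([C@@H]4O[C@H](CO)[C@@H](O)[C@H]4O)nn3)cc2o1` has not been measured; it differs from compound 2 by phenyl in place of methyl on an aromatic carbon. For the measured compounds named here, no step between measured compounds exists here, so no clear direction can be read from the data, and a step no larger than the scatter is expected. Compound 3 is expected to give 300000 nM, within 100000 nM to 1000000 nM. The expected step is an at least 1.2-fold lower number from compound 2 to compound 3 (0.10 log units; that floor lies within the scatter).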

Compound 3, half-maximal inhibitory concentration: > 332000 nM
Compound 3: only a limit was reported (the forecaster's own chance of this, stated with the estimate: 80%); at least 1.1-fold (0.04 log units) between middle value and limit.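

Compound 2 and compound 3 both give only limits in this assay, so the step from methyl to phenyl cannot be read. The compounds shown leave open what concentration, if any, gives half-maximal inhibition.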